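The compounds below may be only part of what the source reports. "The series", "measured", "known", "first", "only" and "open" are said of these compounds alone.

Measured so far:
compound 1 `c1cc(Nc2nccc(-c3ccco3)n2)cc(-n2ccnc2)c1` with 800 nM
compound 2 `Oc1ccc(Nc2nccc(-c3cccnc3)n2)cc1` with 5100 nM

In a functional assay for inhibition, with Homo sapiens as the target (on this read-out higher numbers stand for weaker inhibition and lower numbers for stronger inhibition), compound 1 gives 800 nM, the lowest of the two numbers; the nearest is compound 2, whose 5100 nM is a gap that lies beyond the scatter. The account follows the step from compound 1 to compound 3 `CC1CCN(c2cccc(Nc3nccc(-c4ccco4)n3)c2)CC1`, which differs from compound 1 in one place: 4-methylpiperidin-1-yl in place of 1H-imidazol-1-yl on an aromatic carbon. Among the measured compounds shown here, no step of this kind between measured compounds is available, so nothing measured tells how much the group entering here is worth. The expectation is therefore cautious: in this assay compound 3 is estimated at 1200 nM, with a range from 250 nM to 6000 nM. That estimate means a step of a 1.5-fold higher number from compound 1 to compound 3 (0.18 log units; within the scatter), expected to stay close to the scatter rather than to move compound 3 clearly away from compound 1 in either direction.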

Compound 3, half-maximal inhibitory concentration: 5000 nM
For compound 3 the middle estimate is 4.2-fold (0.62 log units) below the measured one; the measured number falls inside the stated range.
By their numbers in this assay, from the lowest: compound 1; then compounds 3 and 2 (each within the scatter of the next).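

In this assay the change to 4-methylpiperidin-1-yl in place of 1H-imidazol-1-yl gives a 6.3-fold higher number from compound 1 to compound 3 (0.80 log units; beyond the scatter) and so weaker inhibition. This shows that the group on this aromatic carbon, meta to a large group, matters to the read-out, and that on the core of compound 1 the five-membered aromatic ring serves better than the six-membered non-aromatic ring. Nothing available explains this loss, and a single pair cannot separate ring size from aromatic character or the count of hydrogen-bond acceptors.

Going by these compounds, it remains open whether another aromatic ring, such as pyrazole or pyridine, would match 1H-imidazol-1-yl here. Equally open, on these data alone, is how morpholine, or piperidine without its methyl group, would compare with 4-methylpiperidin-1-yl.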